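A few compounds are considered here, and "the series" means these few. Any claim that something is new, unique, unknown or untested is made for them only; others in the source may bear on it.

Values in a functional assay on CLL cells (Homo sapiens) for cytotoxicity, read by MTT assay, with a stated time of 48 h; a higher number here means that more compound is needed for the effect, a lower number that less compound is needed:
- compound 1 `C=C(CC)C(=O)c1ccc(OCC(=O)Nc2ccc(C(=O)O)cn2)c(Cl)c1Cl`: 14900 nM
- compound 2 `C=C(CC)C(=O)c1ccc(OCC(=O)Nc2nc3ccccc3s2)c(Cl)c1Cl`: 1500 nM
- compound 3 `C=C(CC)C(=O)c1ccc(OCC(=O)Nc2ccc(C(=O)O)c(O)c2)c(Cl)c1Cl`: > 25000 nM (a limit of the assay, not a number)

Of the two actual numbers, compound 2 has the lower, 1500 nM. The next step leads to compound 4 `C=C(CC)C(=O)c1ccc(OCC(=O)NC(CS)C(=O)OCC)c(Cl)c1Cl`: 1-(ethoxycarbonyl)-2-sulfanylethyl in place of 1,3-benzothiazol-2-yl on an amide-type nitrogen. In words, 1-(ethoxycarbonyl)-2-sulfanylethyl replaces 1,3-benzothiazol-2-yl on an amide-type nitrogen. Among the compounds with values here, one measured step bears on this: a 9.9-fold lower number from compound 1 to compound 2 (1.00 log units; beyond the scatter), a modest step at the same nitrogen, with the number falling as 1,3-benzothiazol-2-yl entered. Within the data shown here, compound 4 loses that group, and no measured compound carries the entering one. With little certainty, the step expected in this assay is therefore a modest move to a higher number, estimated as a 3.3-fold higher number from compound 2 to compound 4 (0.52 log units; beyond the scatter). For compound 4 the estimated value is 5000 nM, with an expected range of 1200 nM to 20000 nM.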

Compound 4, half-maximal effective concentration: 4800 nM
Compound 4: middle estimate off by 1.0-fold (0.02 log units), on the high side; the range from low to high includes it.
By their numbers in this assay, from the lowest: compound 2; then compound 4; then compound 1. At a limit, above all of these: compound 3.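

A ring is not required on this amide-type nitrogen in this assay: 1-(ethoxycarbonyl)-2-sulfanylethyl has none, yet it gives a 3.1-fold lower number from compound 1 to compound 4 (0.49 log units; beyond the scatter). It does not match 1,3-benzothiazol-2-yl, with a 3.2-fold higher number from compound 2 to compound 4 (0.51 log units; beyond the scatter), so the open chain recovers part of the difference between the two ring-bearing groups. Nothing measured here gives a cause for either step.

Going by these compounds, whether the sulfanyl group or the ethyl ester drives this remains open. A free carboxylic acid in place of the ester, or a hydroxyl in place of the sulfanyl, would separate the two.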